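Trimming the Sulfonamide Substituent to a Bare Nitrogen

The source may hold more compounds than are shown below. What is called first, only, known or untested is meant among the compounds shown, and "the series" means these compounds.

Compound 1, `CCCNS(=O)(=O)c1ccc(Nc2ncc3c(n2)N(C2CCCC2)[C@H](CC)C(=O)N3C)cc1`, gives 17.8 nM in an assay for inhibition of serine/threonine-protein kinase PLK2 (Homo sapiens), read by FRET and Z'-LYTE, with a stated time of 1 h; on this read-out higher numbers stand for weaker inhibition and lower numbers for stronger inhibition.
Compound 2, `CC[C@@H]1C(=O)N(C)c2cnc(Nc3ccc(S(=O)(=O)NCCO)cc3)nc2N1C1CCCC1`, gives 7.86 nM in this assay.
Compound 3, `CC[C@@H]1C(=O)N(C)c2cnc(Nc3ccc(S(=O)(=O)NC4CCCC4)cc3)nc2N1C1CCCC1`, gives 23.9 nM in this assay.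

Compound 3 holds the highest of the three numbers, though its gap to compound 1 lies within the scatter; only compound 2 sits clearly apart from it. All three share one core and differ solely in the group on the sulfonamide nitrogen. Compound 4, `CC[C@@H]1C(=O)N(C)c2cnc(Nc3ccc(S(N)(=O)=O)cc3)nc2N1C1CCCC1`, carries no group there at all: hydrogen in place of cyclopentyl on a sulfonamide nitrogen.

Two measured steps speak to this change, both at the same nitrogen. The step of a 1.3-fold higher number from compound 1 to compound 3 (0.13 log units; within the scatter) shows that trading propyl for cyclopentyl barely moves the number, whereas a 3.0-fold higher number from compound 2 to compound 3 (0.48 log units; beyond the scatter) shows that the 2-hydroxyethyl analogue stands lower by a modest margin. Removing the cyclopentyl entirely has no direct precedent among these compounds, and a hydrogen is not a 2-hydroxyethyl group, so the expected step is uncertain. Compound 4 is nevertheless expected to give a somewhat lower number than compound 3, a change of about a 1.8-fold lower number from compound 3 to compound 4 (0.26 log units; within the scatter), because with smaller substituents compound 2 gave 7.86 nM and compound 1 gave 17.8 nM. The estimate for compound 4 in this assay is 13 nM, within a range of 5 nM to 32 nM.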

Compound 4, half-maximal inhibitory concentration: 10.2 nM
Compound 4: middle estimate off by 1.3-fold (0.11 log units), on the high side; low and high end bracket the measured number.
By their numbers in this assay, from the lowest: compounds 2, 4, 1 and 3 (each within the scatter of the next, the first and the last beyond it).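

In this assay, stripping the sulfonamide nitrogen down to a hydrogen does not push the number up, and the step runs the other way, with a 2.3-fold lower number from compound 3 to compound 4 (0.37 log units; beyond the scatter); the nitrogen therefore needs no substituent to give a number in this range. The same bare nitrogen cannot be told apart from the two chains, as both a 1.3-fold higher number from compound 2 to compound 4 (0.11 log units; within the scatter) and a 1.7-fold lower number from compound 1 to compound 4 (0.24 log units; within the scatter) show, so neither 2-hydroxyethyl nor propyl is separated from hydrogen at this position. Cyclopentyl is the only one of the four groups with any step beyond the scatter, to hydrogen and to 2-hydroxyethyl, yet compound 1 goes against any simple ordering by the size of the group, since its propyl chain stays within the scatter of both cyclopentyl and hydrogen.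

Nothing shown here accounts for these steps. On these data alone, it remains open how a methyl, an acetyl, or a longer chain ending in an amine or a carboxylic acid on this nitrogen would compare, and whether the same steps would hold with a group other than cyclopentyl on the shared core.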